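A Larger Oxygen Substituent on a Cytotoxic Compound

The compounds below may be only part of what the source reports. "The series", "measured", "known", "first", "only" and "open" are said of these compounds alone.

This study tests a small set of compounds in a functional assay on U-937/GTB cells (Homo sapiens) for cytotoxicity; a higher number here means a weaker inhibitor, a lower number a stronger inhibitor. Compound 1 `C=CC[n+]1cn(C)c2nc[nH]/c(=N\OC)c21` gives > 80000 nM, which is a limit of the assay and not a number. Two compounds give real numbers. Compound 2 `CC(C)=CCC/C(C)=C/CC/C(C)=C/CC/C(C)=C/C[n+]1cn(C)c2ncnc(N)c21` gives 3170 nM and compound 3 `CO/N=c1\[nH]cnc2ncn(C/C=C(\C)CC/C=C(\C)CC/C=C(\C)CCC=C(C)C)c12` gives 3310 nM, two values that lie within the usual scatter of each other. Compound 3 therefore stands level with compound 2 in this assay.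

The next compound is compound 4 `CC(C)=CCC/C(C)=C/CC/C(C)=C/CC/C(C)=C/Cn1cnc2nc[nH]/c(=N\OCc3ccccc3)c21`. It keeps the shared core and the chain of compound 3 and differs at one place: phenyl in place of hydrogen on a saturated chain carbon bound to an oxygen. In words, this puts phenyl in place of hydrogen on a saturated chain carbon bound to an oxygen, so methoxy becomes benzyloxy.

Within the data shown here, no pair of measured compounds here shows what this change does, so the expectation has little to lean on. The nearest guide is compound 3 at 3310 nM, the measured compound that most resembles compound 4. The expected change, a 1.2-fold higher number from compound 3 to compound 4 (0.08 log units; within the scatter), is none beyond the scatter, and no clear direction is predicted. For compound 4 the estimated value is 4000 nM, with an expected range from 1500 nM to 12000 nM.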

Compound 4, half-maximal inhibitory concentration: 11200 nM
Beside the measured number, compound 4's estimate is 2.8-fold (0.45 log units) below it; measured number inside the range.
By their numbers in this assay, from the lowest: compounds 2 and 3 (each within the scatter of the next); then compound 4. At a limit, above all of these: compound 1.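

In this assay, the oxygen substituent turns out not to be a neutral place for change: with phenyl in place of hydrogen on a saturated chain carbon bound to an oxygen, methoxy becomes benzyloxy, and the result is a 3.4-fold higher number from compound 3 to compound 4 (0.53 log units; beyond the scatter). Among these compounds, this is the first pair in the set that differs in one place, so it gives the first direct reading of this position, and that reading is a modest weakening, not a loss of all measurable effect, since compound 4 still gives a real number of 11200 nM. Nothing measured here accounts for why the number rises with this change.

On these data alone, one step cannot separate the effect of the aromatic ring from the effect of simply extending the group, so it remains open how an ethoxy or a longer plain-chain group on the oxygen would compare with methoxy and benzyloxy. As far as these compounds go, it also remains open whether a benzyloxy group whose ring carries a fluorine, an amine or a carboxylic acid would move the number up or down, and whether the same change would have a similar effect with a shorter chain on the shared core.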